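The source may hold more compounds than are shown below. What is called first, only, known or untested is meant among the compounds shown, and "the series" means these compounds.

Measured so far: compound 1 `O[C@@H]1[C@H](O)CS[C@H]1Cn1cnc2c(NCc3cccc(Br)c3)ncnc21` with 6.1% and compound 2 `O[C@@H]1[C@H](O)CS[C@H]1Cn1cnc2c(NCc3cccc(F)c3)nc(Cl)nc21` with 17.6% in an assay on CHO cells for displacement of a labelled ligand from adenosine receptor A3 (Homo sapiens), with a stated time of 60 min, tested at 10 uM; on this read-out lower numbers stand for less inhibition and higher numbers for more inhibition at the one concentration tested (going by the name of the read-out).

Compound 2 stands highest of the two numbers in this assay; its nearest neighbour is compound 1, whose number is lower by a margin beyond the usual scatter. Going by the values given here, no step between two measured compounds that differ in a single place is available here, so the effect of any one change has not been isolated.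

Compound 3 `O[C@@H]1[C@H](O)CS[C@H]1Cn1cnc2c(NCc3cccc(F)c3)ncnc21` differs from compound 2 in one place: hydrogen in place of chloro on an aromatic carbon.

In this assay compound 3 is expected to show a small downward step, a number 8.6 percentage points lower from compound 2 to compound 3 (within the scatter), partly because compound 1, which also lacks the chloro group, gives only 6.1% there. The estimate for compound 3 in this assay is 9%, with a range from 0% to 20%.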

Compound 3, a percentage reported as inhibition, at one concentration (the size of the read-out at that concentration, not a potency): 8.7%
The estimate for compound 3 lay 0.3 percentage points above the measured number, within the range that was stated.
By their numbers in this assay, from the lowest: compounds 1, 3 and 2 (each within the scatter of the next, the first and the last beyond it).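

In this assay, going by these compounds alone, hydrogen in place of chloro, on the aromatic carbon between two ring nitrogen atoms, gives a number 8.9 percentage points lower from compound 2 to compound 3 (within the scatter) and so provides the first single-place reading at this position: the chloro group does not separate the two compounds beyond the scatter. Fluoro in place of bromo on an aromatic carbon gives a number 2.6 percentage points higher from compound 1 to compound 3 (within the scatter) and also stays within the scatter, so the wider gap between compound 1 and compound 2 cannot be assigned to either single change. No measurement is available that bears on the reason for these steps.

The compounds shown leave open whether a different group at this position, such as an amine or a methoxy group, would move the number beyond the scatter. They also leave open whether chloro at this position would give a similar step alongside bromo in place of fluoro.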